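Inverting One Stereocentre in a Weak Antagonist Series

A few compounds are considered here, and "the series" means these few. Any claim that something is new, unique, unknown or untested is made for them only; others in the source may bear on it.

Compound 1: `COc1cc(CN(CC(N)=O)C(=O)c2cccs2)ccc1OCc1ccc(F)cc1` — 9100 nM
Compound 2: `COc1cc(CN(C(=O)c2cccs2)[C@@H](C(N)=O)c2ccccc2)ccc1OCc1ccc(F)cc1` — limit, > 100000 nM
Compound 3: `COc1cccc(CN(C(=O)c2cccs2)[C@H](C(N)=O)c2ccccc2)c1` — 54000 nM
Compound 4: `COc1cccc(CN(C(=O)c2cccs2)[C@@H](C(N)=O)c2ccccc2)c1` — not yet measured

In an assay on HEK293 cells for antagonist activity at transient receptor potential cation channel subfamily M member 8 (Homo sapiens), read by calcium flux (a higher number here means a weaker inhibitor, a lower number a stronger inhibitor), compound 1 gives 9100 nM. Compound 2 reaches only a limit of the assay, > 100000 nM. Compound 3 gives 54000 nM, the highest of the two numbers shown, its nearest neighbour being compound 1. Among the compounds with values here, the only measured step, an at least 10-fold higher number from compound 1 to compound 2 (1.04 log units; beyond the scatter), adds a phenyl group and leaves configuration untouched. Compound 4 differs from compound 3 in configuration alone: the two compounds have the same atoms and bonds and differ only in configuration as drawn: 1 of 1 stereo elements differ; a stereocentre at a saturated chain carbon is drawn S in compound 3 and R in compound 4. Within the data shown here, no measured step bears on such an inversion, so the expected change is none beyond the scatter: no change at the digits printed from compound 3 to compound 4 (within the scatter). Compound 4 is therefore estimated at 54000 nM, within a range from 20000 nM to 150000 nM.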

Compound 4, half-maximal inhibitory concentration: 1700 nM
The estimate for compound 4 lay 32-fold (1.50 log units) above the measured number; the measured number lies below the stated range.
By their numbers in this assay, from the lowest: compound 4; then compound 1; then compound 3. At a limit, above all of these: compound 2.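

At this saturated chain carbon, configuration alone matters a great deal in this assay: with no atom or bond changed, drawing the centre R rather than S gives a 32-fold lower number from compound 3 to compound 4 (1.50 log units; beyond the scatter). Drawn with the same configuration as compound 4, compound 2 stands at a limit of the assay, > 100000 nM. That configuration is therefore not enough on its own, since hydrogen in place of (4-fluorobenzyl)oxy on an aromatic carbon gives an at least 58-fold lower number from compound 2 to compound 4 (1.76 log units; beyond the scatter).

As far as these compounds go, whether inversion has a similar effect with a methyl group or a cyclohexyl ring in place of the phenyl remains open. So does how an ethoxy group would compare with that hydrogen.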